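This account rests on a few compounds, and the source may have more. Where it says the series, first, only, none or still open, it means among the compounds named here.

Working notes on the series. In a physicochemical assay for solubility, measured as kinetic solubility, with a stated time of 1 h, at pH 7.4 (a higher number here means a more soluble compound, a lower number a less soluble compound), compound 3 (`O=C(NC1=NN(c2ccc(Cl)c(Cl)c2)CC1)c1cccnn1`) gives 67000 nM, within the scatter of compound 1 (`CC(=O)N[C@@H](C)C(=O)NC1=NN(c2ccc(Cl)c(Cl)c2)CC1`) at 58000 nM and well clear of compound 2 (`O=C(NC1=NN(c2ccc(Cl)c(Cl)c2)CC1)c1cccnc1`) at 4000 nM. Compound 4 (`O=C(NC1=NN(c2ccc(Cl)c(Cl)c2)CC1)c1cncnc1`) differs from compound 3 as follows: pyrimidin-5-yl in place of pyridazin-3-yl on a carbonyl carbon. In words, pyrimidin-5-yl stands in place of pyridazin-3-yl on a carbonyl carbon. Exchanges at this carbonyl carbon have been large, as in a 15-fold lower number from compound 1 to compound 2 (1.16 log units; beyond the scatter) and a 17-fold higher number from compound 2 to compound 3 (1.22 log units; beyond the scatter), but a 1.2-fold higher number from compound 1 to compound 3 (0.06 log units; within the scatter) stayed within the scatter. For the measured compounds named here, no measured compound carries pyrimidin-5-yl, so the estimate stays close to compound 3, with a wide range. The expected step is small and downward, a 1.5-fold lower number from compound 3 to compound 4 (0.17 log units; within the scatter), with none beyond the scatter anticipated. For compound 4 the estimated value is 45000 nM, with an expected range of 14000 nM to 110000 nM.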

Compound 4, solubility: 8000 nM
For compound 4 the middle estimate is 5.6-fold (0.75 log units) above the measured one; the measured number lies below the stated range.
By their numbers in this assay, from the lowest: compounds 2 and 4 (each within the scatter of the next); then compounds 1 and 3 (each within the scatter of the next).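

In this assay the two rings on the carbonyl carbon have the same atoms, joined differently, yet the exchange gives an 8.4-fold lower number from compound 3 to compound 4 (0.92 log units; beyond the scatter) and so the arrangement of the ring atoms matters at this position, not only their number. The series also shows a 7.3-fold lower number from compound 1 to compound 4 (0.86 log units; beyond the scatter) and a 2.0-fold higher number from compound 2 to compound 4 (0.30 log units; within the scatter) so the high number of compound 3 does not extend to every ring of this composition. Nothing on hand accounts for the gap between these two rings. Still open, going by these compounds, is how pyrazin-2-yl behaves here, and whether an amine on the pyrimidin-5-yl ring changes the number.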